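The source may report more compounds than this note shows. Statements on the series, on what has been measured and on what is new or still open speak of the compounds shown alone.

Measured so far:
compound 1 `CC(C)NS(=O)(=O)c1ccc2c(c1)C(n1ccccc1=O)=CC(C)(C)O2` gives 1950 nM in a functional assay with Rattus norvegicus as the target; on this read-out lower numbers stand for an effect already at smaller amounts and higher numbers for an effect only at larger amounts of compound
compound 2 `CC1(C)C=C(n2ccccc2=O)c2cc(S(=O)(=O)Nc3ccccc3)ccc2O1` gives 13.2 nM in this assay
compound 3 `CC1(C)C=C(n2ccccc2=O)c2cc(S(=O)(=O)Nc3ccc(C#N)cc3)ccc2O1` gives 1380 nM in this assay

Compound 3 stands second highest of the three numbers: close to compound 1, a 1.4-fold lower number from compound 1 to compound 3 (0.15 log units; within the scatter), and far from compound 2, a 100-fold higher number from compound 2 to compound 3 (2.02 log units; beyond the scatter).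

Compound 4 `CC1(C)C=C(n2ccccc2=O)c2cc(S(=O)(=O)Nc3ccc([N+](=O)[O-])cc3)ccc2O1` differs from compound 3 by nitro in place of cyano on an aromatic carbon. Among the compounds with values here, no measured step swaps one such group for another; the only step bearing on that aromatic carbon is a 100-fold higher number from compound 2 to compound 3 (2.02 log units; beyond the scatter), where adding cyano moved the number up sharply. A nitro in that place is expected to leave compound 4 near compound 3, so the step of a 1.0-fold higher number from compound 3 to compound 4 (0.01 log units; within the scatter) is expected to stay within the scatter. Compound 4 is estimated at 1400 nM, with a range from 400 nM to 5000 nM in this assay.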

Compound 4, half-maximal effective concentration: 10200 nM
Compound 4: middle estimate off by 7.3-fold (0.86 log units), on the low side; the whole stated range lies below it.
By their numbers in this assay, from the lowest: compound 2; then compounds 3 and 1 (each within the scatter of the next); then compound 4.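

In this assay the two groups on this aromatic carbon are not equivalent: nitro in place of cyano still moves the number beyond the scatter (a 7.4-fold higher number from compound 3 to compound 4 (0.87 log units; beyond the scatter)). Against the unsubstituted phenyl, the nitro group gives the largest step in the series so far (a 770-fold higher number from compound 2 to compound 4 (2.89 log units; beyond the scatter)). Compound 4 also separates from the isopropyl sulfonamide (a 5.2-fold higher number from compound 1 to compound 4 (0.72 log units; beyond the scatter)), whereas the cyano analogue stayed within the scatter of that compound.

Open, from the compounds shown here alone, is whether an amine or a methoxy group at this place would bring the number back toward compound 2. Nothing measured here accounts for the gap between nitro and cyano.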